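Piperazine nitrogen substituent in the amide-linked series

The source may report more compounds than this note shows. Statements on the series, on what has been measured and on what is new or still open speak of the compounds shown alone.

Measured compounds in a functional assay on MCF7 cells (Homo sapiens) for cytotoxicity, read by MTT assay, with a stated time of 24 h; on this read-out lower numbers stand for stronger inhibition and higher numbers for weaker inhibition:
compound 1 `Cn1nnnc1SCC(=O)Nc1ccc(-c2nc(-c3ccccc3)c(-c3ccccc3)n2C)cc1` gives 4.5 ug/mL
compound 2 `Cn1c(-c2ccc(NC(=O)CN3CCN(c4ccccc4)CC3)cc2)nc(-c2ccccc2)c1-c1ccccc1` gives 10.7 ug/mL

Compound 2 stands at the highest of the two numbers, its nearest neighbour being compound 1, with the step of a 2.4-fold higher number from compound 1 to compound 2 (0.38 log units; beyond the scatter). Compound 3 `Cn1c(-c2ccc(NC(=O)CN3CCN(Cc4ccc(Cl)cc4)CC3)cc2)nc(-c2ccccc2)c1-c1ccccc1` differs from compound 2 by 4-chlorobenzyl in place of phenyl on an amine nitrogen in a ring. Among the compounds with values here, no measured step touches the group on the amine nitrogen in the ring; the only step, from the tetrazolyl-sulfanyl chain to the piperazine, concerns a different part. Within the data shown here, with no bearing step, the expected change from compound 2 to compound 3 in this assay is a 1.2-fold lower number from compound 2 to compound 3 (0.08 log units; within the scatter), within the scatter. Compound 3 is estimated at 9 ug/mL, from 3.5 ug/mL to 25 ug/mL.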

Compound 3, half-maximal inhibitory concentration: 21 ug/mL
Beside the measured number, compound 3's estimate is 2.3-fold (0.37 log units) below it, within the range that was stated.
By their numbers in this assay, from the lowest: compound 1; then compounds 2 and 3 (each within the scatter of the next).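

In this assay, 4-chlorobenzyl in place of phenyl on the amine nitrogen in the ring gives a 2.0-fold higher number from compound 2 to compound 3 (0.29 log units; within the scatter), so the step stays within the usual scatter. Within the data shown here, this is the first reading at this position, and it does not separate the two aromatic substituents, although the entering group has 8 heavy atoms against 6. No supporting data bear on this result.

As far as these compounds go, the added carbon and the chlorine change together here, so their separate contributions remain open. Also open, from the compounds shown here alone, is whether unsubstituted benzyl, methyl or a carboxylic acid on a short chain at this nitrogen would move the number beyond the scatter.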